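Swapping the nitrophenyl arm for a thiophene ring

The compounds below may be only part of what the source reports. "The series", "measured", "known", "first", "only" and "open" are said of these compounds alone.

Compound 1 `O=[N+]([O-])c1ccc(C2=NN(C(=S)Nc3ccccc3)C(c3ccc4c(c3)OCCO4)C2)cc1` is the weaker of the two measured compounds: in a functional assay on HT-29 cells (Homo sapiens) for antiproliferative activity, read by MTT assay, with a stated time of 48 h (on this read-out lower numbers stand for stronger inhibition of growth and higher numbers for weaker inhibition of growth), compound 1 gives 153000 nM, the highest of the two numbers. Its nearest neighbour, compound 2 `COc1cccc(C2=NN(C(=S)Nc3ccccc3)C(c3ccc4c(c3)OCCO4)C2)c1`, gives 2920 nM in this assay. Among the measured compounds shown here, the one step known so far, a 52-fold lower number from compound 1 to compound 2 (1.72 log units; beyond the scatter), is large and lies well beyond the scatter.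

Compound 3 `S=C(Nc1ccccc1)N1N=C(c2cccs2)CC1c1ccc2c(c1)OCCO2` is the next compound to be tested. It differs from compound 1 in one place: thiophen-2-yl in place of 4-nitrophenyl on a carbon with a double bond to nitrogen. For the measured compounds named here, the only measured step that bears on this change is the one from compound 1 to compound 2, where replacing the same 4-nitrophenyl group with another aryl ring brought a sharp fall. A fall in the same direction is therefore expected for compound 3 in this assay, though its size is uncertain since thiophen-2-yl has not yet been tried. The expected step is a 13-fold lower number from compound 1 to compound 3 (1.11 log units; beyond the scatter). Compound 3 is estimated to give 12000 nM, within a range from 2500 nM to 60000 nM.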

Compound 3, concentration for 50% growth inhibition: 188000 nM
For compound 3 the middle estimate is 16-fold (1.19 log units) below the measured one, and the stated range ends below it.
By their numbers in this assay, from the lowest: compound 2; then compounds 1 and 3 (each within the scatter of the next).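

At this position, swapping 4-nitrophenyl for thiophen-2-yl makes no real difference in this assay, with a 1.2-fold higher number from compound 1 to compound 3 (0.09 log units; within the scatter). So moving away from 4-nitrophenyl does not by itself bring a lower number, and the benefit belongs to 3-methoxyphenyl among the three groups seen here, as a 64-fold higher number from compound 2 to compound 3 (1.81 log units; beyond the scatter) shows. Nothing at hand explains why 3-methoxyphenyl stands apart from the other two groups.

The compounds shown leave open whether the low number of compound 2 depends on the methoxy group itself, or on where it sits on the phenyl ring. A plain phenyl, a 4-methoxyphenyl or a 3-hydroxyphenyl on this same carbon, with the rest of the core of compound 2 unchanged, would help to separate these two possibilities.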